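Bromo for methoxy on the aryl group: compound 4

The source may report more compounds than this note shows. Statements on the series, on what has been measured and on what is new or still open speak of the compounds shown alone.

Measured compounds, all in a functional assay on HeLa cells (Homo sapiens) for inhibition, read by MTT assay, with a stated time of 24 h; on this read-out lower numbers stand for stronger inhibition and higher numbers for weaker inhibition:
compound 1 `CCOC(=O)C1=Cc2ccccc2OC1(OCc1cc(-c2ccc(F)cc2F)no1)C(F)(F)F`, limit of the assay, > 150000 nM
compound 2 `CCOC(=O)C1=Cc2ccccc2OC1(OCc1cc(-c2ccc(C)cc2)no1)C(F)(F)F`, limit of the assay, > 150000 nM
compound 3 `CCOC(=O)C1=Cc2ccccc2OC1(OCc1cc(-c2ccc(OC)cc2)no1)C(F)(F)F`, limit of the assay, > 150000 nM

Compound 3 stands at a limit only, so its place among the others is not readable; the limit of > 150000 nM in this assay, at which 3 of the 3 values shown sit, holds all three values. Compound 4 `CCOC(=O)C1=Cc2ccccc2OC1(OCc1cc(-c2ccc(Br)cc2)no1)C(F)(F)F` differs from compound 3 by bromo in place of methoxy on an aromatic carbon. The steps that touch this position, a step that the two limits leave unreadable from compound 1 to compound 3 and a step that the two limits leave unreadable from compound 2 to compound 3, are both unreadable between limits, so no size of change can be drawn from them. Compound 4 is therefore expected to sit near the same limit, with a step that the limit leaves unreadable from compound 3 to compound 4 as the expected step. The estimate for compound 4 is 200000 nM, within 50000 nM to 1000000 nM.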

Compound 4, half-maximal inhibitory concentration: 52300 nM
Estimate against measurement, compound 4: 3.8-fold (0.58 log units) above; low and high end bracket the measured number.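

In this assay, among the compounds shown here, the 4-bromophenyl group gives the first step that can be read: an at least 2.8-fold lower number from compound 3 to compound 4 (0.45 log units; beyond the scatter), an at least 2.8-fold lower number from compound 2 to compound 4 (0.45 log units; beyond the scatter) and an at least 2.8-fold lower number from compound 1 to compound 4 (0.45 log units; beyond the scatter). A change in the aryl group alone can thus bring a compound on the shared core off the limit, whereas the steps among compound 1, compound 2 and compound 3 cannot be read. The other compounds stay at that limit: the limit of > 150000 nM in this assay, at which 3 of the 4 values shown sit.

From the compounds shown here alone, whether this shift is particular to bromo remains open, and chloro, iodo, an amine or a carboxylic acid at the same place would test it. Going by these compounds, the full size of each step also remains open, as only its minimum can be read.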